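The source may report more compounds than this note shows. Statements on the series, on what has been measured and on what is new or still open speak of the compounds shown alone.

Measured compounds:
compound 1, `COc1ccc(Cl)cc1N1CCN(C(=O)c2oc(C)nc2-c2ccccc2F)CC1`, 153 nM
compound 2, `CC(=O)c1ccc(N2CCN(C(=O)c3oc(C)nc3-c3ccccc3)CC2)cc1`, "not active" (no number reported)
compound 3, `COc1cccc(-c2nc(C)oc2C(=O)N2CCN(c3cccc(Cl)c3)CC2)c1`, "not active" (no number reported)

All three were tested in a functional assay on HL-60 cells (Homo sapiens) for inhibition, read by MTT assay, with a stated time of 72 h; on this read-out lower numbers stand for stronger inhibition and higher numbers for weaker inhibition. Of them only compound 1 gives a number, 153 nM. In this assay compound 2 is reported as "not active" (no number reported), with no concentration attached. Compound 3 is reported in the same way, as "not active" (no number reported). Compound 2 therefore stands with one other compound in the group for which no half-maximal concentration was reached, apart from compound 1, which does give a value.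

Compound 4, `Cc1nc(-c2ccccc2)c(C(=O)N2CCN(c3ccccc3)CC2)o1`, has not yet been measured. It differs from compound 2 in one place: hydrogen in place of acetyl on an aromatic carbon. Among the measured compounds shown here, no step between two measured compounds shows what this change does in this assay, so the expectation rests on compound 2 alone. The expected outcome is no shift beyond the scatter, in either direction, and most likely another report without a number. Compound 4 is estimated at 30000 nM, in a range from 8000 nM to 100000 nM.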

Compound 4, half-maximal inhibitory concentration: 39.1 nM
The estimate for compound 4 lay 770-fold (2.88 log units) above the measured number, and the stated range ends above it.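

No new step can be read here: compound 2 has no number in this assay, so the change from 4-acetylphenyl to phenyl that leads to compound 4 cannot be given a size. The compounds shown leave open how far acetyl itself matters on other cores. No supporting measurement bears on this result.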